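Swapping the alkyne terminus: pentylphenyl out, cyclopropyl in

This account rests on a few compounds, and the source may have more. Where it says the series, first, only, none or still open, it means among the compounds named here.

Measured compounds:
Compound 1 `O=c1[nH]c(=O)n(CCC(CO)CO)cc1-c1ccco1` in a functional assay on HeLa cells (Homo sapiens) for antiproliferative activity, read by MTT assay, with a stated time of 72 h (a higher number here means a weaker inhibitor, a lower number a stronger inhibitor), gives > 100000 nM, which is a limit of the assay rather than a number.
Compound 2 `O=c1[nH]c(=O)n(CCC(CO)CO)cc1-c1cccs1` gives 7800 nM.
Compound 3 `CCCCCc1ccc(C#Cc2cn(CCC(COC(C)=O)COC(C)=O)c(=O)n(C(=O)c3ccccc3)c2=O)cc1` gives 79100 nM.

Compound 3 stands highest of the two numbers that were read as numbers; compound 2 gives a lower number, and compound 1 sits at the limit (the limit of > 100000 nM in this assay, at which 1 of the 3 values shown sits). Among the compounds with values here, the only step measured between neighbours is an at least 12-fold lower number from compound 1 to compound 2 (1.10 log units; beyond the scatter), and it concerns the ring attached to the aromatic carbon of the core, not the triple-bonded carbon.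

Compound 4 `CC(=O)OCC(CCn1cc(C#CC2CC2)c(=O)n(C(=O)c2ccccc2)c1=O)COC(C)=O` differs from compound 3 in one place: cyclopropyl in place of 4-pentylphenyl on a triple-bonded carbon. Within the data shown here, none of the measured steps alters a group on the triple-bonded carbon, so no measured step bears directly on this change, and the step from compound 1 to compound 2 offers only a sense of how far a single swap of a terminal group can move the number. With compound 3 already close to the limit, the account expects that compound 4 gives a number no lower than compound 3, and possibly only a limit; the expected step is a 1.4-fold higher number from compound 3 to compound 4 (0.14 log units; within the scatter).

Compound 4 is therefore estimated at 110000 nM, in the range 35000 nM to 350000 nM.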

Compound 4, half-maximal inhibitory concentration: > 100000 nM
Compound 4 gave a limit, no number (the forecaster's own chance of this, stated with the estimate: 50%); the middle value is on the limit's open side.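

In this assay, this is the first change shown at the triple-bonded carbon, and cyclopropyl in place of 4-pentylphenyl gives an at least 1.2-fold higher number from compound 3 to compound 4 (0.10 log units; that floor lies within the scatter), so the printed floor of the step does not establish that compound 4 is weaker than compound 3. What the change does show is that replacing the 11 heavy atoms of 4-pentylphenyl with the 3 of cyclopropyl brings no measurable gain in strength at this position, with no number read for compound 4. From the compounds shown here alone, the size of the step stays unknown because the result for compound 4 is cut off at the top of the measured range: the limit of > 100000 nM in this assay, at which 2 of the 4 values shown sit.

The compounds shown leave open whether the ring or the pentyl chain of 4-pentylphenyl carries the activity of compound 3, a question that a plain phenyl or a longer alkyl chain on the triple-bonded carbon would address. Within the data shown here, they also leave open how an amine at this terminus would read, and how the alkyne compounds relate to compound 1 and compound 2, since no single-place step connects the two pairs.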